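The compounds below may be only part of what the source reports. "The series", "measured", "known", "first", "only" and "open" are said of these compounds alone.

Working notes on the series.

Compound 1 `O=C(CSc1snnc1-c1ccc(F)cc1F)Nc1ccccc1[N+](=O)[O-]`, compound 2 `O=C(CSc1snnc1-c1ccc(Cl)cc1Cl)Nc1ccccc1[N+](=O)[O-]` and compound 3 `O=C(CSc1snnc1-c1ccc(F)cc1F)Nc1ccccc1Br` have been run in an ADME assay on MT4 cells (Homo sapiens) for cytotoxicity; a higher number here means that more compound is tolerated, a lower number that less compound is tolerated; compound 4 `O=C(CSc1snnc1-c1ccc(Cl)cc1Cl)Nc1ccccc1Br` has not. In this assay compound 1 gives 165000 nM. Compound 2 reaches only a limit of this assay, > 283000 nM, and no number. In this assay compound 3 gives 144000 nM.

The change from compound 1 to compound 2 is 2,4-dichlorophenyl in place of 2,4-difluorophenyl on an aromatic carbon. It gave an at least 1.7-fold higher number from compound 1 to compound 2 (0.23 log units; that floor lies within the scatter); the step is bounded from below only because of the limit of > 283000 nM in this assay, at which 1 of the 3 values shown sits.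

The cores of compound 3 and compound 1 differ by bromo in place of nitro on an aromatic carbon, which gave a 1.1-fold lower number from compound 1 to compound 3 (0.06 log units; within the scatter).

Compound 4 stands to compound 3 as compound 2 stands to compound 1: 2,4-dichlorophenyl in place of 2,4-difluorophenyl on an aromatic carbon. The place line of this change reads word for word as it does from compound 1 to compound 2, so it is the same change made on the other core. Of the two cores, compound 3 sits close to compound 1, as a 1.1-fold lower number from compound 1 to compound 3 (0.06 log units; within the scatter) shows, so the same change is expected to carry over with about the same size.

For compound 4 the step of a 1.8-fold higher number from compound 3 to compound 4 (0.26 log units; within the scatter) is expected, resting on an at least 1.7-fold higher number from compound 1 to compound 2 (0.23 log units; that floor lies within the scatter) for the same change and on the starting point of compound 3, 144000 nM. The estimate for compound 4 in this assay is 260000 nM, with a likely range from 130000 nM to 520000 nM; a limit rather than a number is considered about as likely as not, because compound 2 gave > 283000 nM.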

Compound 4, half-maximal cytotoxic concentration: >= 146000 nM
Compound 4 was reported as a limit (the forecaster's own chance of this, stated with the estimate: 50%); the middle value is on the limit's open side.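

Compound 4 reaches only a limit in this assay, >= 146000 nM, and no number. Among these compounds, on the core of compound 3, 2,4-dichlorophenyl in place of 2,4-difluorophenyl gave an at least 1.0-fold higher number from compound 3 to compound 4 (0.00 log units; that floor lies within the scatter), and beside the earlier step this gives no ground to claim that the change behaves differently on the two cores: the same change on two cores in this assay, an at least 1.7-fold higher number (0.23 log units; that floor lies within the scatter) from compound 1 to compound 2 and an at least 1.0-fold higher number (0.00 log units; that floor lies within the scatter) from compound 3 to compound 4; the limit leaves it open whether they differ What this shows is only that both cores allow a step of the printed floor sizes, with neither floor beyond the scatter; it does not show that the change carries over with the same size, or that it raises the number on either core, and the step between compound 2 and compound 4 cannot be read, since both ends are limits.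

On these data alone, the true size of the change on each core stays open, as does whether the bromo and nitro cores really match once the dichloro compounds have numbers rather than limits. Also open is how tolerance in this assay would respond if an amine or a carboxylic acid stood in place of the bromo or nitro group on the shared core, since the compounds shown cover only these halogen and nitro variations.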